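The compounds below may be only part of what the source reports. "The series", "measured", "known", "first", "only" and "open" are said of these compounds alone.

Measured so far: compound 1 `CC(C)[C@H](NC(=O)CCN(C)C)c1cccc(F)c1N1CCN(C(=O)[C@@H]2CN(C(C)C)C[C@H]2c2ccc(Cl)cc2)CC1`, 5.3 nM; compound 2 `Cc1ccc(N2CCN(C(=O)[C@@H]3CNC[C@H]3c3ccc(Cl)cc3)CC2)c([C@@H](NC(=O)CCN(C)C)C(C)C)c1`, 7.2 nM.

Among the measured compounds shown here, in an assay on HEK293 cells for displacement of a labelled ligand from Melanocortin receptor 4 (Homo sapiens) (on this read-out lower numbers stand for stronger inhibition and higher numbers for weaker inhibition), compound 1 gives 5.3 nM, and compound 2 gives 7.2 nM; the two numbers lie within the usual scatter of each other, so compound 1 stands level with the only other measured compound. Compound 3 `CC(C)[C@H](NC(=O)CCN(C)C)c1cccc(F)c1N1CCN(C(=O)[C@@H]2CN(C(C)C)C[C@H]2c2cccc(Cl)c2)CC1` differs from compound 1 in one place: 3-chlorophenyl in place of 4-chlorophenyl on a saturated ring carbon. For the measured compounds named here, no measured pair shows this change, so the expectation rests on the change alone. A modest weakening is expected, the step from compound 1 to compound 3 being a 2.8-fold higher number from compound 1 to compound 3 (0.45 log units; beyond the scatter). Compound 3 is therefore estimated at 15 nM, within a range from 4 nM to 60 nM in this assay.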

Compound 3, inhibition constant: 370 nM
Compound 3: the middle estimate sits 25-fold (1.39 log units) below what was measured; measured number outside the range, above it.
By their numbers in this assay, from the lowest: compounds 1 and 2 (each within the scatter of the next); then compound 3.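

In this assay, 3-chlorophenyl in place of 4-chlorophenyl on this saturated ring carbon gives a 70-fold higher number from compound 1 to compound 3 (1.84 log units; beyond the scatter) even though the two groups have the same atoms, so the result at this position depends strongly on where the chlorine sits on the phenyl ring. The earlier compounds shown here both carry 4-chlorophenyl and could not show this. Nothing at hand explains the loss. As far as these compounds go, whether 2-chlorophenyl, 4-fluorophenyl or unsubstituted phenyl would hold the number of compound 1 or lose as much as compound 3 stays open.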